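The source may report more compounds than this note shows. Statements on the series, on what has been measured and on what is new or still open speak of the compounds shown alone.

In a functional assay on SMMC-7721 cells (Homo sapiens) for cytotoxicity, read by MTT assay, with a stated time of 24 h (a higher number here means a weaker inhibitor, a lower number a stronger inhibitor), compound 1 `COc1ccc(/C=C2\CN(C)C/C(=C\c3cccnc3)C2=O)c(OC)c1OC` gives 13700 nM. Compound 3 `O=C1/C(=C/c2ccncc2)CN(S(=O)(=O)c2ccc([N+](=O)[O-])cc2)C/C1=C\c1ccccc1F` gives 15800 nM, which lies within the usual scatter of the compound 1 value, so the two cannot be ranked. Compound 2 `O=C1/C(=C/c2cccnc2)CN(S(=O)(=O)c2ccc([N+](=O)[O-])cc2)C/C1=C\c1ccccc1F` reads > 20000 nM, which is a limit of the assay and not a number.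

Going by the values given here, the only measured step between close relatives is an at least 1.2-fold lower number from compound 2 to compound 3 (0.10 log units; that floor lies within the scatter). It places pyridin-4-yl where pyridin-3-yl stood, on a double-bonded chain carbon, so it says nothing directly about the next change.

Compound 4 `N#Cc1ccc(S(=O)(=O)N2C/C(=C\c3ccncc3)C(=O)/C(=C/c3ccccc3F)C2)cc1` differs from compound 3 at another place: cyano in place of nitro on an aromatic carbon. In words, cyano replaces nitro on an aromatic carbon, turning 4-nitrophenyl into 4-cyanophenyl. Among the compounds with values here, no measured step covers this swap, so the numbers offer no size for it, and no shift beyond the scatter in this assay is expected. The estimated step is a 1.1-fold lower number from compound 3 to compound 4 (0.05 log units; within the scatter). For compound 4 the estimated value is 14000 nM, with an expected range from 6000 nM to 20000 nM.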

Compound 4, half-maximal inhibitory concentration: 16200 nM
Compound 4: the middle estimate sits 1.2-fold (0.06 log units) below what was measured, and the stated range covers the measured number.
By their numbers in this assay, from the lowest: compounds 1, 3 and 4 (each within the scatter of the next). At a limit, above all of these: compound 2.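

In this assay, replacing nitro with cyano on this aromatic carbon, which turns 4-nitrophenyl into 4-cyanophenyl, gives a 1.0-fold higher number from compound 3 to compound 4 (0.01 log units; within the scatter). Going by these compounds alone, this is the first measured change at this position, as the earlier step concerned only the pyridine ring on the double-bonded chain carbon. Within this one pair the two groups cannot be told apart, and compound 4, which carries no nitro group, gives 16200 nM.

Going by these compounds, whether an amine or a carboxylic acid on this same aromatic carbon would move the number beyond the scatter remains open, as does whether the cyano swap would behave the same way with pyridin-3-yl in place of pyridin-4-yl. That second comparison would start from compound 2, which stands at a limit and not at a number: the limit of > 20000 nM in this assay, at which 1 of the 4 values shown sits.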